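From compound 2 to compound 3: a 4-cyanophenyl swap

The source may hold more compounds than are shown below. What is called first, only, known or untested is meant among the compounds shown, and "the series" means these compounds.

In a functional assay (aorta) with Oryctolagus cuniculus as the target (on this read-out lower numbers stand for tighter binding and higher numbers for weaker binding), compound 1 (`COc1cc(C(C)=O)ccc1OCCCCCCN1CCC(C(c2ccc(F)cc2)c2ccc(F)cc2)CC1`) gives 6.31 nM and compound 2 (`CCc1ccc(OCCCN2CCC(C(c3ccc(F)cc3)c3ccc(F)cc3)CC2)c(OC)c1`) gives 2.51 nM as the lower of the two numbers, a gap beyond the scatter. Compound 3 (`N#Cc1ccc(OCCCN2CCC(C(c3ccc(F)cc3)c3ccc(F)cc3)CC2)cc1`) carries 4-cyanophenyl in place of 4-ethyl-2-methoxyphenyl on an oxygen on a saturated carbon. For the measured compounds named here, no measured pair shows this change, so what follows is judgement only. A moderate rise in this assay is expected, an estimated step of a 4.0-fold higher number from compound 2 to compound 3 (0.60 log units; beyond the scatter) that probably lies beyond the scatter. For compound 3 the expected value is 10 nM (estimated range 2.5 nM to 40 nM).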

Compound 3, dissociation constant: 5.01 nM
The estimate for compound 3 lay 2.0-fold (0.30 log units) above the measured number; the range from low to high includes it.
By their numbers in this assay, from the lowest: compounds 2, 3 and 1 (each within the scatter of the next, the first and the last beyond it).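

In this assay, for the compounds shown here, 4-cyanophenyl in place of 4-ethyl-2-methoxyphenyl on an oxygen on a saturated carbon gives a 2.0-fold higher number from compound 2 to compound 3 (0.30 log units; within the scatter), the first reading of a change in one place. At this position, the ethyl and methoxy groups can both leave and a nitrile can enter while the number stays within the scatter. Nothing at hand bears on why the two numbers sit so close. From the compounds shown here alone, the separate contributions of ethyl, methoxy and nitrile remain open, since all three change in one step. Also open, going by these compounds, is whether a carboxylic acid or an amine in place of the nitrile would stay within the scatter.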